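Two methyl groups in place of a ring chlorine

The source may hold more compounds than are shown below. What is called first, only, known or untested is meant among the compounds shown, and "the series" means these compounds.

Compound 1 `O=C(Nc1ccc(Cl)cc1)NS(=O)(=O)c1ccc(Cl)s1` is the reference point of this small set. In a functional assay on the whole organism (6C3HED cells, Mus musculus) for inhibition, at a dose of 150 mg/kg by the oral route (on this read-out higher numbers stand for more inhibition at the one dose given (going by the name of the read-out) and lower numbers for less inhibition), compound 1 gives 58%, the highest of the two numbers measured. Going by the values given here, its only measured neighbour is compound 2 `COc1csc(S(=O)(=O)NC(=O)Nc2ccc(Cl)cc2)c1`, which in this assay gives 36%; the step of a number 22 percentage points lower from compound 1 to compound 2 (beyond the scatter) is the sole measured step at the group on the sulfonyl sulfur. Compound 3 `Cc1cc(S(=O)(=O)NC(=O)Nc2ccc(Cl)cc2)sc1C` has not yet been measured. It differs from compound 1 as follows: 4,5-dimethylthiophen-2-yl in place of 5-chlorothiophen-2-yl on a sulfonyl sulfur. Among the compounds with values here, the one measured step concerns a different replacement at the same sulfonyl sulfur and therefore bears on it only loosely, but it shows that altering this group lowered the read-out by a modest amount. Compound 3 is therefore expected to come out somewhat lower than compound 1, a step within the scatter not being excluded, with the expected step being a number 13 percentage points lower from compound 1 to compound 3 (beyond the scatter). On this basis compound 3 is estimated at 45%, with a range from 20% to 70%.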

Compound 3, a percentage reported as inhibition, in the whole organism at one dose (the size of the read-out at that dose, not a potency): 42%
Compound 3: the middle estimate sits 3 percentage points above what was measured; measured number inside the range.
By their numbers in this assay, from the lowest: compounds 2 and 3 (each within the scatter of the next); then compound 1.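

In this assay, a second replacement on the sulfonyl sulfur also lowers the read-out, with a number 16 percentage points lower from compound 1 to compound 3 (beyond the scatter) as the result, so the drop is no longer tied to 4-methoxythiophen-2-yl alone, and 5-chlorothiophen-2-yl stands above both other groups in these three compounds. The two replacing groups cannot be told apart here, with a number 6 percentage points higher from compound 2 to compound 3 (within the scatter) as the printed step, so 4,5-dimethylthiophen-2-yl and 4-methoxythiophen-2-yl give much the same result despite their different substituents. Nothing shown here explains why these groups differ from 5-chlorothiophen-2-yl.

The compounds shown leave open whether the chlorine itself matters or any other group in its place would serve as well, a question that 5-bromothiophen-2-yl or 5-methylthiophen-2-yl could address. They also leave open how a plain phenyl ring or a carboxylic acid on the thiophene would behave on the sulfonyl sulfur.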